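Swapping Trifluoromethyl for Tert-Butyl on the Aryl Tail

A few compounds are considered here, and "the series" means these few. Any claim that something is new, unique, unknown or untested is made for them only; others in the source may bear on it.

Compound 1 `COc1cccc(CNCCCNc2ccnc3cc(-c4ccc(C(F)(F)F)cc4)ccc23)c1O` was tested in a physicochemical assay for solubility, with a stated time of 18 h, at pH 7.4 (a lower number here means a less soluble compound, a higher number a more soluble compound), where compound 1 gives 32000 nM. Compound 3 `FC(F)(F)c1ccc(-c2ccc3c(NCCCNCc4ccco4)ccnc3c2)cc1` gives 32000 nM, so compound 1 stands level with compound 3, the two sharing the highest of the three numbers; the step of no change at the digits printed from compound 1 to compound 3 (within the scatter) puts furan-2-yl in place of 2-hydroxy-3-methoxyphenyl on a saturated chain carbon bound to an amine nitrogen. Compound 2 `COc1ccc(F)cc1CNCCCNc1ccnc2cc(Cc3ccc(F)cc3Cl)ccc12` differs from compound 1 in several places. In this assay compound 2 gives 4200 nM, the lowest value. Compound 4 `COc1cccc(CNCCCNc2ccnc3cc(-c4ccc(C(C)(C)C)cc4)ccc23)c1O` awaits measurement and differs from compound 1 by tert-butyl in place of trifluoromethyl on an aromatic carbon. Going by the values given here, no measured step touches this position, so the data offer no direct guide. The value for compound 4 is expected near 20000 nM, between 6000 nM and 40000 nM, an estimated step of a 1.6-fold lower number from compound 1 to compound 4 (0.20 log units; within the scatter).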

Compound 4, solubility: 32000 nM
Compound 4: the middle estimate sits 1.6-fold (0.20 log units) below what was measured, and the stated range covers the measured number.
By their numbers in this assay, from the lowest: compound 2; then compounds 1, 3 and 4 (each within the scatter of the next).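

In this assay, going by these compounds alone, the change from 4-(trifluoromethyl)phenyl to 4-(tert-butyl)phenyl gives no change at the digits printed from compound 1 to compound 4 (within the scatter) and is the first measured step at this position. On the core of compound 1, this aromatic carbon therefore takes either trifluoromethyl or tert-butyl with no difference in this read-out. No measurement here explains why the two groups match. As far as these compounds go, whether the same holds on other parts of the molecule also stays open, as the step was read on one background only. A carboxylic acid or an amine at this position remains untested among the compounds shown.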